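Dichlorophenyl in Place of Methylphenyl on a Weak Compound

This account rests on a few compounds, and the source may have more. Where it says the series, first, only, none or still open, it means among the compounds named here.

Compound 1 `Cc1ccc(N2CCN(C(=O)c3oc(C)nc3-c3ccccc3)CC2)cc1` is one of two compounds in this set tested in a functional assay on HL-60 cells (Homo sapiens) for inhibition, read by MTT assay, with a stated time of 72 h; a lower number here means a stronger inhibitor, a higher number a weaker inhibitor. In this assay compound 1 reaches only the limit of > 1000 nM, which is the edge of what the measurement can report rather than a number. This puts compound 1 at the limit of > 1000 nM in this assay, at which 1 of the 2 values shown sits. For the measured compounds named here, the only other measured compound, compound 2 `Cc1nc(-c2ccc(F)cc2)c(C(=O)N2CCN(c3ccc(Cl)cc3)CC2)o1`, is recorded in this assay as "not active" (no number reported), again without a number. Going by the values given here, no two measured compounds differ in a single place, so there is no measured step to lean on.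

Compound 3 `Cc1nc(-c2ccccc2)c(C(=O)N2CCN(c3cc(Cl)cc(Cl)c3)CC2)o1` has not yet been measured. It differs from compound 1 by 3,5-dichlorophenyl in place of 4-methylphenyl on an amine nitrogen in a ring. With compound 1 at a limit and compound 2 without a number, nothing measured shows how large such a change is in this assay. The step expected here is a step that the limit leaves unreadable from compound 1 to compound 3, which is taken as no change beyond the usual scatter. Compound 3 is therefore estimated at 3000 nM, with a range from 800 nM to 20000 nM, and most likely again only a limit.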

Compound 3, half-maximal inhibitory concentration: 41.8 nM
Compound 3: the middle estimate sits 72-fold (1.86 log units) above what was measured, outside the stated range (below it).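

For the compounds shown here, putting 3,5-dichlorophenyl in place of 4-methylphenyl on the amine nitrogen in a ring gives, in this assay, an at least 23-fold lower number from compound 1 to compound 3 (1.37 log units; beyond the scatter), which shows that the group at this position can make a large difference to the read-out, something the earlier compounds could not show. Going by these compounds alone, compound 3 is also the first compound here with an actual number rather than a limit or a bare "not active", so it gives any further change to this series a firm point of comparison. Compound 1 gives only a limit, so the step sets a lower bound on the size of the change and does not measure its full size: the limit of > 1000 nM in this assay, at which 1 of the 3 values shown sits.

The step swaps one whole group for another, so the compounds shown cannot tell whether both chlorine atoms are needed, or whether the loss of the methyl group plays any part. As far as these compounds go, how this position would respond to a phenyl ring with a single chlorine, or to methoxy groups in place of the chlorines, stays open.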